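From methoxy to ethoxy: a cell tolerance question

The source may report more compounds than this note shows. Statements on the series, on what has been measured and on what is new or still open speak of the compounds shown alone.

In a functional assay on MDBK cells (Bos taurus) for cytotoxicity (a lower number here means that less compound is tolerated, a higher number that more compound is tolerated), compound 1 `CO/N=C(\C#N)C(=O)NCC1=NOC(C(C)(C)C)C1` gives > 100 ug/mL, which is a limit and not a number. Compound 3 `CO/N=C(/C#N)C(=O)NCC1=NOC(C(C)(C)C)C1` gives > 100 ug/mL, again a limit. Among the measured compounds shown here, compound 2 `C=CCO/N=C(\C#N)C(=O)NCC1=NOC(c2ccccc2)C1` supplies the only plain number, 100 ug/mL. Going by these compounds, compound 1 therefore stands at the tolerated end of the values seen so far, though its true position remains unknown.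

The next compound, compound 4 `CCO/N=C(\C#N)C(=O)NCC1=NOC(C(C)(C)C)C1`, makes one small change to compound 1: methyl in place of hydrogen on a saturated chain carbon bound to an oxygen on an unsaturated carbon. In words, methyl takes the place of hydrogen on a saturated chain carbon bound to an oxygen on an unsaturated carbon, turning methoxy into ethoxy.

For the measured compounds named here, only one measured step is available, a step that the two limits leave unreadable from compound 1 to compound 3. It concerns the drawing of a double bond rather than this chain, and it has no readable size, so it offers little guidance. With compound 2 at 100 ug/mL and given (the limit of > 100 ug/mL in this assay, at which 2 of the 3 values shown sit), no step beyond the usual scatter is expected in this assay. The estimated change is a number no higher from compound 1 to compound 4 (the limit leaves the size open). The assay may well report only a limit again. For compound 4, the expected value is 100 ug/mL, with an estimated range from 50 ug/mL to 200 ug/mL.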

Compound 4, half-maximal cytotoxic concentration: > 100 ug/mL
Compound 4: a limit, no number; the forecaster's own chance of this, stated with the estimate: 75%; the middle value lies on the limit itself.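

In this assay compound 4 gives > 100 ug/mL, which is a limit and not a number. Compound 1 also has only a limit, so the step between compound 1 and compound 4 cannot be read. The compounds shown leave open how much of either compound the cells tolerate, and whether changing methoxy to ethoxy alters that tolerance at all.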